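A few compounds are considered here, and "the series" means these few. Any claim that something is new, unique, unknown or untested is made for them only; others in the source may bear on it.

Measured so far:
- Compound 1 `Cc1ccc(-c2cn(C/C=C3\OC(=O)C(OCc4ccccc4)=C3OCc3ccccc3)nn2)cc1`: in a functional assay on U-937 cells (Homo sapiens) for antiproliferative activity, read by MTT assay, with a stated time of 24 h (on this read-out lower numbers stand for stronger inhibition and higher numbers for weaker inhibition), compound 1 gives > 100000 nM, a limit of the assay rather than a number.
- Compound 2 `O=C1NC(O)(CCn2cc(C3=CCCCC3)nn2)C(OCc2ccccc2)=C1OCc1ccccc1`: in this assay compound 2 gives > 100000 nM, again a limit and not a number.

Compound 2 thus stands at the limit, as does every value shown here (the limit of > 100000 nM in this assay, at which 2 of the 2 values shown sit). Compound 3 `O=C1NC(O)(CCn2cc(-c3ccccc3)nn2)C(OCc2ccccc2)=C1OCc1ccccc1` differs from compound 2 by phenyl in place of cyclohex-1-en-1-yl on an aromatic carbon. Within the data shown here, no step between measured compounds is available, so no change beyond the usual scatter is expected; the step from compound 2 to compound 3 is estimated at a number no higher from compound 2 to compound 3 (the limit leaves the size open). Compound 3 is therefore expected at 100000 nM, within a range of 30000 nM to 300000 nM, most likely reported only as a limit.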

Compound 3, half-maximal inhibitory concentration: 21500 nM
Compound 3: the middle estimate sits 4.7-fold (0.67 log units) above what was measured, outside the stated range (below it).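

In this assay, the group on this aromatic carbon of the five-membered ring matters: a six-membered aromatic ring in place of a non-aromatic one, phenyl for cyclohex-1-en-1-yl, gives an at least 4.6-fold lower number from compound 2 to compound 3 (0.66 log units; beyond the scatter). Among these compounds, compound 3 is the first compound here to give a number rather than a limit. The full size of the step stays open, as compound 2 gives only a limit: the limit of > 100000 nM in this assay, at which 2 of the 3 values shown sit.

One pair cannot show whether this trend extends to other groups at this position. As far as these compounds go, how a phenyl carrying an amine or a carboxylic acid would read out also remains open.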